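Swapping a cyanophenyl for a methylsulfonyl piperidine

The source may hold more compounds than are shown below. What is called first, only, known or untested is meant among the compounds shown, and "the series" means these compounds.

Of the compounds shown here, three sharing one core have been measured in a physicochemical assay for solubility, in phosphate buffer, at pH 7.4; a lower number here means a less soluble compound, a higher number a more soluble compound. Compound 1 `OCc1cccc(-c2nccnc2OC2CN(c3ccc4ccccc4n3)C2)c1` carries a 3-(hydroxymethyl)phenyl group and gives 29000 nM. Compound 2 `c1ccc(-c2nccnc2OC2CN(c3ccc4ccccc4n3)C2)cc1` gives only a limit of the assay, < 1000 nM. Compound 3 `N#Cc1ccc(-c2nccnc2OC2CN(c3ccc4ccccc4n3)C2)cc1` likewise gives only a limit, < 1000 nM. So compound 3 stands at the limit of < 1000 nM in this assay, at which 2 of the 3 values shown sit, with its true number unknown. The drops are an at least 29-fold lower number from compound 1 to compound 2 (1.46 log units; beyond the scatter) and an at least 29-fold lower number from compound 1 to compound 3 (1.46 log units; beyond the scatter), while the step between the two limits is a step that the two limits leave unreadable from compound 2 to compound 3.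

Compound 4 `CS(=O)(=O)N1CCC(c2nccnc2OC2CN(c3ccc4ccccc4n3)C2)CC1` differs from compound 3 by 1-(methylsulfonyl)piperidin-4-yl in place of 4-cyanophenyl on an aromatic carbon. Among the measured compounds shown here, none of the measured steps involves this entering group, so none bears directly on the change. The two large steps show only that taking away the hydroxymethyl group pushes the number down to the limit. With compound 3 itself at a limit, neither the size nor the direction of this step can be read from the numbers. The value of compound 4 is expected to be 8000 nM, ranging from 1000 nM to 60000 nM. That corresponds to an expected step of an at least 8.0-fold higher number from compound 3 to compound 4 (0.90 log units; beyond the scatter).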

Compound 4, solubility: 181000 nM
Beside the measured number, compound 4's estimate is 23-fold (1.35 log units) below it; measured number above the stated range.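

In this assay, among the compounds shown here, a six-membered non-aromatic ring at this place, next to the ring nitrogen, gives the highest number so far: the 1-(methylsulfonyl)piperidin-4-yl group brings an at least 180-fold higher number from compound 3 to compound 4 (2.25 log units; beyond the scatter) and an at least 180-fold higher number from compound 2 to compound 4 (2.25 log units; beyond the scatter). Both steps start from a limit of the assay, so their true sizes stay unknown: the limit of < 1000 nM in this assay, at which 2 of the 4 values shown sit. The same group also passes the hydroxymethyl compound, with a 6.2-fold higher number from compound 1 to compound 4 (0.80 log units; beyond the scatter), so a hydroxymethyl group on a phenyl ring is not the only way off the limit among these compounds.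

This change removes the aromatic ring and brings in the methylsulfonyl group at once, so the compounds shown cannot say which part goes with the rise. A plain cyclohexyl ring, or a piperidine carrying an acetyl group on its nitrogen, would help separate the two.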